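Methyl Added to a Fluorophenyl Urea: Expected Weaker Effect

This account rests on a few compounds, and the source may have more. Where it says the series, first, only, none or still open, it means among the compounds named here.

Compound 1, `C[C@@H](NC(=O)Nc1ccccc1F)c1ccccc1`, gives 77% in an ADME assay on the whole organism with Oryza sativa as the target, tested at 10 uM (a higher number here means a weaker effect of the compound at the concentration tested, a lower number a stronger effect), the lowest of the three numbers shown. Compound 2, `C[C@@H](NC(=O)Nc1ccccc1Br)c1ccccc1`, gives 94% and compound 3, `C[C@@H](NC(=O)Nc1cc(F)ccc1F)c1ccccc1`, gives 92%. Both neighbours lie beyond the scatter above compound 1: a number 17 percentage points higher from compound 1 to compound 2 (beyond the scatter) and a number 15 percentage points higher from compound 1 to compound 3 (beyond the scatter). Compound 4, `Cc1ccc(NC(=O)N[C@H](C)c2ccccc2)c(F)c1`, differs from compound 1 in one place, (methyl in place of hydrogen on an aromatic carbon). Both measured steps on the same ring raised the number modestly, so a modest rise of similar kind is expected here, though neither step is the same change. The estimated step is a number 10 percentage points higher from compound 1 to compound 4 (within the scatter). Compound 4 is therefore expected to give about 87%, within a range from 74% to 98%.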

Compound 4, a percentage reported as activity, at one concentration (the size of the read-out at that concentration, not a potency): 99%
Beside the measured number, compound 4's estimate is 12 percentage points below it; measured number outside the range, above it.
By their numbers in this assay, from the lowest: compound 1; then compounds 3, 2 and 4 (each within the scatter of the next).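

In this assay, methyl on this aromatic carbon, para to a large group and meta to a fluoro group, gives a number 22 percentage points higher from compound 1 to compound 4 (beyond the scatter). The rise is therefore not confined to the halogen changes: all three single changes to this aromatic ring of compound 1 weaken the effect beyond the scatter, and none goes against that. Nothing available explains this rise. Going by these compounds, it remains open whether the rise belongs to this carbon or to methyl itself, and whether an amine or a methoxy group here would also raise the number.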